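The source may hold more compounds than are shown below. What is called first, only, known or untested is meant among the compounds shown, and "the series" means these compounds.

Compound 1 `O=C(C1CCN(C(=O)C(F)(F)F)CC1)N1N=CCC1c1ccccc1`: > 1.5 h
Compound 2 `O=C(c1cn[nH]c1)N1CCC(C(=O)N2N=CCC2c2ccccc2)CC1`: > 2.75 h
Compound 3 `O=C(c1cocn1)N1CCC(C(=O)N2N=CCC2c2ccccc2)CC1`: > 2.75 h

All three entries in an ADME assay on microsomes (Homo sapiens) for metabolic stability (a higher number here means that the compound lasts longer, a lower number that the compound disappears faster), are limits of the assay, not numbers. Compound 3 stands at > 2.75 h, which is a limit and the upper of the two seen in this series: the limit of > 2.75 h in this assay, at which 2 of the 3 values shown sit.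

The next compound is compound 4 `O=C(c1cc[nH]n1)N1CCC(C(=O)N2N=CCC2c2ccccc2)CC1`, with 1H-pyrazol-3-yl in place of 1,3-oxazol-4-yl on a carbonyl carbon.

The closest measured comparison is a step that the two limits leave unreadable from compound 2 to compound 3. Further off lie a step that the two limits leave unreadable from compound 1 to compound 2 and a step that the two limits leave unreadable from compound 1 to compound 3. None of these gives a size, so no direction can be taken from them.

The expectation therefore rests on compound 2, which carries 1H-pyrazol-4-yl on the same carbonyl carbon and reads > 2.75 h, also a limit. No change beyond the scatter is expected in this assay, and the expected step is a step that the limit leaves unreadable from compound 3 to compound 4. Compound 4 is estimated at 3 h, with an expected range of 1.5 h to 6 h, and the result may well be reported only as a limit.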

Compound 4, half-life: > 2.75 h
Compound 4 ended at the assay's limit; the forecaster's own chance of this, stated with the estimate: 75%; the middle value does not contradict the limit.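

Compound 4 gives > 2.75 h in this assay, which is a limit of the assay. Set against compound 1, compound 2 and compound 3, it yields no readable step. The compounds shown leave open the actual half-lives and whether the groups on the carbonyl carbon differ at all.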